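A Sulfonyl Group Replaces Benzyl on the Ring Nitrogen

The compounds below may be only part of what the source reports. "The series", "measured", "known", "first", "only" and "open" are said of these compounds alone.

Measured compounds:
compound 1, `COc1ccc(-c2cc(=O)c3c(OC)cc(OC)cc3n2Cc2ccccc2)cc1`: a limit only, > 34400 nM
compound 2, `COc1ccc(-c2[nH]c3cc(OC)cc(OC)c3c(=O)c2I)cc1`: a limit only, > 86200 nM
compound 3, `COC(=O)c1cc(=O)c2c(OC)cc(OC)cc2n1S(=O)(=O)c1ccc(C)cc1`: 9700 nM

In a functional assay on SUP-B15 cells (Homo sapiens) for antiproliferative activity, with a stated time of 72 h (a higher number here means that more compound is needed for the effect, a lower number that less compound is needed), compound 1 reaches only a limit, > 34400 nM; this is the point noted as the limit of > 34400 nM in this assay, at which 1 of the 3 values shown sits. Compound 2 likewise gives only a limit in this assay, > 86200 nM, recorded as the limit of > 86200 nM in this assay, at which 1 of the 3 values shown sits. Within the data shown here, compound 3 is the one measured compound with a number in this assay, giving 9700 nM. No two of these compounds differ in a single place, so no measured step is available, and the three values show only that compound 3 yields a number where compound 1 and compound 2 do not.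

Compound 4, `COc1ccc(-c2cc(=O)c3c(OC)cc(OC)cc3n2S(=O)(=O)c2ccc(F)cc2)cc1`, has not been measured in this assay. Compared with compound 1 it shows ((4-fluorophenyl)sulfonyl in place of benzyl on an aromatic nitrogen). Since compound 1 stands at a limit, the step from compound 1 to compound 4 cannot be drawn from data. The step is expected to run toward a lower number, as an at least 2.2-fold lower number from compound 1 to compound 4 (0.36 log units; beyond the scatter), a modest step rather than a large one, because compound 3 with a sulfonyl on an aromatic nitrogen gives 9700 nM. Compound 4 is therefore estimated at 15000 nM in this assay, with a range from 4000 nM to 60000 nM.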

Compound 4, half-maximal effective concentration: > 65500 nM
Compound 4 gave a limit, no number; the forecaster's own chance of this, stated with the estimate: 40%; at least 4.3-fold (0.64 log units) between middle value and limit.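

Compound 4, like compound 1, gives only a limit in this assay, so the step between these two compounds cannot be read. The compounds shown leave open whether (4-fluorophenyl)sulfonyl in place of benzyl on an aromatic nitrogen changes the value in this assay at all, and in which direction.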